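Swapping an aryl amide for a cyclobutyl amide

A few compounds are considered here, and "the series" means these few. Any claim that something is new, unique, unknown or untested is made for them only; others in the source may bear on it.

Compound 1: `Cc1cccc(Cn2c(CN3CCN(C(=O)c4ccc(Cl)cc4)CC3)nc3ccccc32)c1`, 23.2%
Compound 2: `O=C(C1CC1)N1CCN(Cc2nc3ccccc3n2Cc2ccccc2F)CC1`, 40.7%

Of the compounds shown here, two have been measured in an assay on isolated protein for inhibition of aldehyde dehydrogenase 1A1 (Homo sapiens), read by spectrophotometry, tested at 10 uM; on this read-out higher numbers stand for more inhibition at the one concentration tested (going by the name of the read-out) and lower numbers for less inhibition. Compound 1 stands lowest of the two numbers with 23.2%; its nearest neighbour is compound 2, whose 40.7% lies higher by a margin beyond the usual scatter. Within the data shown here, compound 2 differs from compound 1 in more than one place, so no single-change step between measured compounds is available, and only their two values can be compared.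

Compound 3, `Cc1cccc(Cn2c(CN3CCN(C(=O)C4CCC4)CC3)nc3ccccc32)c1`, is not yet measured. It keeps the core of compound 1 and differs from it in one place: cyclobutyl in place of 4-chlorophenyl on a carbonyl carbon. Compound 2, which also carries a small carbocyclic ring on its carbonyl, gives 40.7% in this assay, and this is the only hint available for the direction of the change.

Compound 3 is expected to show a modest gain, with an estimated step of a number 9.8 percentage points higher from compound 1 to compound 3 (within the scatter), though the step could fall within the scatter. The estimate for compound 3 in this assay is 33%, with a range from 15% to 52%.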

Compound 3, a percentage reported as inhibition, at one concentration (the size of the read-out at that concentration, not a potency): 69.1%
Compound 3: middle estimate off by 36.1 percentage points, on the low side; measured number above the stated range.
By their numbers in this assay, from the lowest: compound 1; then compound 2; then compound 3.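

In this assay, the site on a carbonyl carbon whose other neighbours are an amide-type nitrogen in a ring proves highly responsive to the group it carries: with the rest of the structure unchanged, cyclobutyl in place of 4-chlorophenyl gives a step of a number 45.9 percentage points higher from compound 1 to compound 3 (beyond the scatter) in this comparison. The earlier pair could not show this, as compound 1 and compound 2 differ in more than one place, whereas this step ties a large change to one site and shows that a six-membered aromatic ring of carbon only is not needed there for inhibition at the one concentration tested. Nothing available explains the size of this step.

The compounds shown leave open whether the gain is particular to cyclobutyl or would also appear with a cyclohexyl ring, a tert-butyl group or an unsubstituted phenyl ring on the same carbonyl carbon. They also leave open whether the same swap would give a step of similar size if the rest of the structure were different.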